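Compound 1: swapping its trihydroxyphenyl group for 4-nitrophenyl

A few compounds are considered here, and "the series" means these few. Any claim that something is new, unique, unknown or untested is made for them only; others in the source may bear on it.

Measured so far in a functional assay on cells (Erythrocyte, Homo sapiens) for inhibition, read by spectrophotometry and hemolysis, with a stated time of 10 min; on this read-out lower numbers stand for stronger inhibition and higher numbers for weaker inhibition
- compound 1 `O=C(CCCc1nc2ccccc2c(=O)[nH]1)N/N=C/c1cc(O)c(O)c(O)c1` gives 183000000 nM
- compound 2 `COc1cc(/C=N/NC(=O)CCc2nc3ccccc3c(=O)[nH]2)cc(OC)c1OC` gives 682000000 nM
- compound 3 `COc1cc(/C=N/NC(=O)CCCc2nc3ccccc3c(=O)[nH]2)cc(O)c1O` gives 277000000 nM

Compound 1 and compound 3 sit within the scatter of each other at the low end of these values, while compound 2 lies beyond the scatter above compound 1. Compound 4 `O=C(CCCc1nc2ccccc2c(=O)[nH]1)N/N=C/c1ccc([N+](=O)[O-])cc1` is still unmeasured and carries 4-nitrophenyl in place of 3,4,5-trihydroxyphenyl on a carbon with a double bond to nitrogen. Going by the values given here, the one measured step that touches this aromatic ring is a 1.5-fold higher number from compound 1 to compound 3 (0.18 log units; within the scatter) for methyl in place of hydrogen on an oxygen on an aromatic ring, a much smaller change than the one at hand. Among the compounds with values here, compound 2 at 682000000 nM differs from compound 1 in more than one place and offers no clean step, though it shows that higher numbers occur. Within the data shown here, no measured compound carries 4-nitrophenyl, so the margins stay wide. A modest rise in this assay is expected. The estimate amounts to a 2.2-fold higher number from compound 1 to compound 4 (0.34 log units; beyond the scatter) as an expected shift. In this assay the estimated value for compound 4 is 400000000 nM with an expected range of 130000000 nM to 1200000000 nM as the working estimate.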

Compound 4, half-maximal inhibitory concentration: 52000000 nM
For compound 4 the middle estimate is 7.7-fold (0.89 log units) above the measured one, and the stated range ends above it.
By their numbers in this assay, from the lowest: compound 4; then compounds 1 and 3 (each within the scatter of the next); then compound 2.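

In this assay, the group on the carbon with a double bond to nitrogen can move the number beyond the scatter: 4-nitrophenyl in place of 3,4,5-trihydroxyphenyl gives a 3.5-fold lower number from compound 1 to compound 4 (0.55 log units; beyond the scatter) on the shared core. The earlier change on this ring stayed within the scatter, at a 1.5-fold higher number from compound 1 to compound 3 (0.18 log units; within the scatter) in the same assay, and compound 4 now shows that a lower number than that of compound 1 does not need any hydroxyl on this ring. Nothing available accounts for this step.

From the compounds shown here alone, whether the step follows from the nitro group or from the loss of the hydroxyl groups stays open, and a plain phenyl, or an amine or a carboxylic acid in place of the nitro group, would separate the two. Going by these compounds, whether 4-nitrophenyl gives a similar step with a longer chain to the core also stays open.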